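Cytotoxicity notes on the shared core, benzylidene aryl variants

The source may hold more compounds than are shown below. What is called first, only, known or untested is meant among the compounds shown, and "the series" means these compounds.

Compound 1 `O=C(CSc1nnc(-c2ccncc2)o1)N/N=C/c1ccccc1` is the reference point of the pair measured so far. In an ADME assay on NIH3T3 cells (Mus musculus) for cytotoxicity, read by MTT assay, with a stated time of 24 h (on this read-out lower numbers stand for stronger inhibition and higher numbers for weaker inhibition), compound 1 gives 167000 nM, the lowest of the two numbers; the nearest is compound 2 `O=C(CSc1nnc(-c2ccncc2)o1)N/N=C/c1cc(Br)cc(Br)c1O`, which in this assay gives 190000 nM. Within the data shown here, the one step with a reading, a 1.1-fold higher number from compound 1 to compound 2 (0.06 log units; within the scatter), shows that replacing the phenyl on the carbon double-bonded to nitrogen with a substituted aryl left the number where it was.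

Compound 3 `O=C(CSc1nnc(-c2ccncc2)o1)N/N=C/c1ccc(O)c(O)c1` is not yet measured. Its change from compound 1 is 3,4-dihydroxyphenyl in place of phenyl on a carbon with a double bond to nitrogen. The step from compound 1 to compound 2 is the only one that bears on it, and it stayed within the scatter; the same kind of step is therefore expected here, with no movement beyond the scatter in either direction in this assay. Compound 3 is expected to give 170000 nM in this assay, between 80000 nM and 360000 nM, which means an expected step of a 1.0-fold higher number from compound 1 to compound 3 (0.01 log units; within the scatter).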

Compound 3, half-maximal inhibitory concentration: 154000 nM
Estimate against measurement, compound 3: 1.1-fold (0.04 log units) above; the measured number falls inside the stated range.
By their numbers in this assay, from the lowest: compounds 3, 1 and 2 (each within the scatter of the next).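

In this assay a second, quite different aryl group at this place also leaves the number flat, with a 1.1-fold lower number from compound 1 to compound 3 (0.04 log units; within the scatter) and a 1.2-fold lower number from compound 2 to compound 3 (0.09 log units; within the scatter). Among these compounds, compound 3 carries hydrogen-bond donors and acceptors that the phenyl of compound 1 lacks and has no bromine, yet no step among the three compounds leaves the scatter, so at this place on a carbon with a double bond to nitrogen neither the 3,4-dihydroxyphenyl nor the 3,5-dibromo-2-hydroxyphenyl group shifts the reading. No measurement at hand offers an explanation for this flat behaviour.

As far as these compounds go, whether a phenyl carrying an amine or a carboxylic acid, or a saturated alkyl chain in place of the aryl ring, would move the number beyond the scatter remains open. The core stays the same throughout, so the compounds shown say nothing about changes elsewhere in the molecule.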